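A few compounds are considered here, and "the series" means these few. Any claim that something is new, unique, unknown or untested is made for them only; others in the source may bear on it.

Measured in a functional assay on NSCLC cells (Homo sapiens) for inhibition, with a stated time of 48 h; on this read-out lower numbers stand for stronger inhibition of growth and higher numbers for weaker inhibition of growth:
- Compound 1 `COc1ccc2c(c1)/C(=C\c1c(Cl)[nH]c3ccc(N(C)C)cc13)C(=O)N2`: 3020 nM
- Compound 2 `COc1cc2c(cc1C)NC(=O)/C2=C/c1c[nH]c2ccccc12`: 13500 nM
- Compound 3 `COc1cc2c(/C=C3/C(=O)N(C)c4ccccc43)c[nH]c2cc1C`: 6310 nM

Compound 3, at 6310 nM, sits in the middle of these three numbers. Its growth inhibition is weaker than that of compound 1 and stronger than that of compound 2, and both gaps lie just beyond the scatter.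

Compound 4 `COc1cc2c(/C=C3/C(=O)N(C)c4ccc(O)cc43)c[nH]c2cc1C` differs from compound 3 by hydroxy in place of hydrogen on an aromatic carbon. Among the compounds with values here, no measured pair shows this change, so any forecast is uncertain. In this assay, no shift beyond the scatter is expected, only a slight lean towards stronger inhibition. The expected change is a 1.4-fold lower number from compound 3 to compound 4 (0.15 log units; within the scatter). For compound 4 the estimated value is 4500 nM, with an expected range from 1500 nM to 13000 nM.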

Compound 4, concentration for 50% growth inhibition: 6030 nM
For compound 4 the middle estimate is 1.3-fold (0.13 log units) below the measured one; low and high end bracket the measured number.
By their numbers in this assay, from the lowest: compounds 1, 4 and 3 (each within the scatter of the next, the first and the last beyond it); then compound 2.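

In this assay, within the data shown here, hydroxy in place of hydrogen on an aromatic carbon gives a 1.0-fold lower number from compound 3 to compound 4 (0.02 log units; within the scatter), the first step in this set that differs in one place, as no earlier pair did. At this carbon, para to a fused ring, the hydroxy is tolerated: the two numbers lie within the scatter of each other. No measurement here offers a reason for this.

Going by these compounds, whether an amine or a carboxylic acid on this carbon would give a step beyond the scatter stays open. So does how hydroxy would behave on the other carbons of this ring.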